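The compounds below may be only part of what the source reports. "The series", "measured", "known", "first", "only" and "open" are said of these compounds alone.

Compound 3 `Cc1ccc(C(=O)O[C@@H](C(N)=O)C2(C)CO2)c2ccccc12` gives 5000 nM in a functional assay on CHO cells (Cricetulus griseus) for inhibition, read by MTT assay, with a stated time of 96 h (on this read-out higher numbers stand for weaker inhibition and lower numbers for stronger inhibition), the lowest of the two numbers available, though compound 1 `CC1([C@H](OC(=O)c2ccc(F)c3ccccc23)C(N)=O)CO1` with 7000 nM sits within the scatter of it. Compound 2 `C=C(C)[C@@H](OC(=O)c1ccc(C)c2ccccc12)C(N)=O` reaches only the limit > 100000 nM in this assay, so its value is a limit and not a number (the limit of > 100000 nM in this assay, at which 1 of the 3 values shown sits). Among the compounds with values here, the one measured step, an at least 20-fold lower number from compound 2 to compound 3 (1.30 log units; beyond the scatter), is large, but it concerns the 2-methyloxiran-2-yl group on the saturated chain carbon, not the aromatic ring.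

Compound 4 `CC1([C@@H](OC(=O)c2ccc(F)c3ccccc23)C(N)=O)CO1` differs from compound 3 as follows: fluoro in place of methyl on an aromatic carbon. Within the data shown here, no measured step touches this aromatic position, so the expectation rests on compound 3 alone and on compound 1, which carries the same fluoro group and gives 7000 nM, within the scatter of compound 3. Compound 4 is therefore expected to give 6000 nM in this assay, between 2000 nM and 18000 nM, a step of a 1.2-fold higher number from compound 3 to compound 4 (0.08 log units; within the scatter) that is expected to stay within the scatter.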

Compound 4, half-maximal inhibitory concentration: 7000 nM
For compound 4 the middle estimate is 1.2-fold (0.07 log units) below the measured one, within the range that was stated.
By their numbers in this assay, from the lowest: compounds 3, 1 and 4 (each within the scatter of the next). At a limit, above all of these: compound 2.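

In this assay, within the data shown here, the first direct comparison at this aromatic carbon, para to a large group, puts fluoro in place of methyl and gives a 1.4-fold higher number from compound 3 to compound 4 (0.15 log units; within the scatter), so this read-out does not separate the two groups here. A second pair has the same atoms and bonds, with a stereocentre at a saturated chain carbon drawn S in one compound and R in the other, and it gives no change at the digits printed from compound 1 to compound 4 (within the scatter), so the drawn configuration at that carbon shows no difference beyond the scatter. This pair needs one caution: the fact that one of compounds 1 and 4 is drawn with a defined configuration and the other without, at the place where they differ.

Going by these compounds, whether a larger or differently built group at this aromatic carbon, such as an amine, a carboxylic acid or a longer chain, would keep the number in this range stays open. Also open, on these data alone, is whether the 2-methyloxiran-2-yl group has the same large effect when fluoro, not methyl, sits on the aromatic carbon.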